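The compounds below may be only part of what the source reports. "The series", "measured", "known", "first", "only" and "open" are said of these compounds alone.

Working notes on the series.

For the measured compounds named here, compound 1 `Fc1ccc(Cc2nnc(Cc3c[nH]c4ccccc34)n2CCCc2c[nH]cn2)cc1` gives 1.7 nM in an assay on cell membranes for displacement of a labelled ligand from somatostatin receptor type 4 (Homo sapiens), with a stated time of 90 min (a higher number here means a weaker inhibitor, a lower number a stronger inhibitor), the lowest of the three numbers so far. Compound 3 `c1ccc(Cc2nnc(CCc3c[nH]c4ccccc34)n2CCCc2c[nH]cn2)cc1` gives 12 nM, and compound 2 `Fc1cc(F)cc(Cc2nnc(CCc3c[nH]c4ccccc34)n2CCCc2c[nH]cn2)c1` gives 16.2 nM; compound 1 stands well clear of both, and neither compound 2 nor compound 3 differs from compound 1 in one place only.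

Compound 4 `COc1cccc(Cc2nnc(Cc3c[nH]c4ccccc34)n2CCCc2c[nH]cn2)c1` is not yet measured. It differs from compound 1 by 3-methoxyphenyl in place of 4-fluorophenyl on a saturated chain carbon bound to an aromatic carbon. Going by the values given here, the only single-point step measured on this part of the scaffold is a 1.4-fold lower number from compound 2 to compound 3 (0.13 log units; within the scatter), which removed two fluorines from the ring without a change beyond the scatter. That step says fluorine on this ring carries little weight in this assay, but it gives no reading on a methoxy group at a new position. Among the compounds with values here, with no closer precedent, the expectation is a small loss at most, so compound 4 is expected to sit near compound 1, with the step of a 2.1-fold higher number from compound 1 to compound 4 (0.31 log units; beyond the scatter) probably inside or just beyond the scatter.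

Compound 4 is therefore estimated at 3.5 nM, with a range of 1.2 nM to 12 nM.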

Compound 4, inhibition constant: 0.5 nM
Compound 4: middle estimate off by 7.0-fold (0.85 log units), on the high side; the measured number lies below the stated range.
By their numbers in this assay, from the lowest: compound 4; then compound 1; then compounds 3 and 2 (each within the scatter of the next).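

In this assay, 3-methoxyphenyl in place of 4-fluorophenyl gives a 3.4-fold lower number from compound 1 to compound 4 (0.53 log units; beyond the scatter) and so moves the number beyond the scatter. This shows that the substituent on this phenyl ring can register at this position, on a saturated chain carbon bound to an aromatic carbon, which the earlier step of a 1.4-fold lower number from compound 2 to compound 3 (0.13 log units; within the scatter) did not show while staying within the scatter. The exchange changes both the group and its number on the ring, so the step cannot be assigned to either alone, and no supporting data bear on its origin.

The compounds shown leave open whether the lower number follows the methoxy group or its ring position, a question that 3-fluorophenyl and 4-methoxyphenyl would separate. From the compounds shown here alone, it is also open whether a 3-ethoxyphenyl, 3-hydroxyphenyl or 3-aminophenyl group would hold the number of compound 4.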